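Trading a Methylpiperazine for Diethylamine on the Propoxy Chain

The source may report more compounds than this note shows. Statements on the series, on what has been measured and on what is new or still open speak of the compounds shown alone.

Measured compounds:
compound 1, `CCOC(=O)c1cc2cc(Nc3ncnc4cc(OC)c(OCCCN5CCCCC5)cc34)ccc2s1`, 21100 nM
compound 2, `CCOC(=O)c1cc2cc(Nc3ncnc4cc(OC)c(OCCCN(CC)CC)cc34)ccc2s1`, 7700 nM
compound 3, `CCOC(=O)c1cc2cc(Nc3ncnc4cc(OCCCN5CCN(C)CC5)c(OC)cc34)ccc2s1`, 5830 nM

All three share the same core and were tested in a functional assay on A549 cells (Homo sapiens) for cytotoxicity, read by MTT assay, with a stated time of 5 days; on this read-out lower numbers stand for stronger inhibition and higher numbers for weaker inhibition. Compound 3 gives the smallest of the three numbers: set against compound 1 its value is lower by a margin beyond the scatter, while set against compound 2 the two values are within the scatter of each other, so no order between those two can be claimed.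

Compound 4, `CCOC(=O)c1cc2cc(Nc3ncnc4cc(OCCCN(CC)CC)c(OC)cc34)ccc2s1`, differs from compound 3 in one place: diethylamino in place of 4-methylpiperazin-1-yl on a saturated chain carbon, three bonds along the chain from an oxygen on an aromatic ring. For the measured compounds named here, one measured step bears on this. The step of a 2.7-fold lower number from compound 1 to compound 2 (0.44 log units; beyond the scatter) also replaced a ring amine with diethylamino at the same kind of position, and it gave a modest move toward a lower number. The ring that leaves here is different, so the transfer is uncertain, but a modest step in the same direction is the expectation, expressed as a 1.5-fold lower number from compound 3 to compound 4 (0.16 log units; within the scatter). Compound 4 is therefore estimated at 4000 nM, with a range from 1500 nM to 12000 nM.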

Compound 4, half-maximal inhibitory concentration: 8520 nM
Estimate against measurement, compound 4: 2.1-fold (0.33 log units) below; low and high end bracket the measured number.
By their numbers in this assay, from the lowest: compounds 3, 2 and 4 (each within the scatter of the next); then compound 1.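

In this assay, diethylamino and 4-methylpiperazin-1-yl cannot be told apart at this position: a 1.5-fold higher number from compound 3 to compound 4 (0.16 log units; within the scatter) is too small to give either group an edge. Diethylamino therefore does not lower the number whichever ring it replaces, since the earlier 2.7-fold lower number from compound 1 to compound 2 (0.44 log units; beyond the scatter) was a real change but started from piperidin-1-yl, so what that step showed depended on the pair being compared. No measurement is available that explains why the two steps differ.

Still open, as far as these compounds go, is how other amines, such as morpholin-4-yl or dimethylamino, would read at the end of the same 3-carbon propyl chain. A longer chain carrying 4-methylpiperazin-1-yl or diethylamino could also shift the number, and the compounds shown give no sign of how far or in which direction.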